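A few compounds are considered here, and "the series" means these few. Any claim that something is new, unique, unknown or untested is made for them only; others in the source may bear on it.

Compound 3 `CCCSc1nc(N/N=C/c2c[nH]c3ccccc23)c2nnn(Cc3ccccc3)c2n1` gives 7410 nM in a functional assay on MGC-803 cells (Homo sapiens) for antiproliferative activity, read by MTT assay, with a stated time of 72 h (on this read-out lower numbers stand for stronger inhibition and higher numbers for weaker inhibition), and stands alongside compound 2 `CCCSc1nc(N/N=C/c2ccc([N+](=O)[O-])cc2)c2nnn(Cc3ccccc3)c2n1`, which gives 10100 nM in this assay; the step of a 1.4-fold lower number from compound 2 to compound 3 (0.13 log units; within the scatter) lies within the scatter. Compound 1 `CCCSc1nc(N/N=C/c2ccccc2F)c2nnn(Cc3ccccc3)c2n1` reached only the limit > 64000 nM in this assay. Compound 4 `CCCSc1nc(N/N=C/c2cccc(Cl)c2)c2nnn(Cc3ccccc3)c2n1` carries 3-chlorophenyl in place of 1H-indol-3-yl on a carbon with a double bond to nitrogen. Within the data shown here, the steps that bear on this change are an at least 8.6-fold lower number from compound 1 to compound 3 (0.93 log units; beyond the scatter) and an at least 6.3-fold lower number from compound 1 to compound 2 (0.80 log units; beyond the scatter), both beyond the scatter, and they show that a substituted phenyl can sit far behind the indole, although compound 2 is itself a substituted phenyl whose number is close to that of compound 3. The step of a 4.0-fold higher number from compound 3 to compound 4 (0.61 log units; beyond the scatter) is therefore expected to run toward a higher number. Compound 4 is estimated at 30000 nM, within a range from 8000 nM to 80000 nM.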

Compound 4, half-maximal inhibitory concentration: > 64000 nM
Compound 4 was reported as a limit; the forecaster's own chance of this, stated with the estimate: 35%; at least 2.1-fold (0.32 log units) between middle value and limit.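

At this position, 3-chlorophenyl falls clearly behind 1H-indol-3-yl, with an at least 8.6-fold higher number from compound 3 to compound 4 (0.93 log units; beyond the scatter), and behind 4-nitrophenyl, with an at least 6.3-fold higher number from compound 2 to compound 4 (0.80 log units; beyond the scatter). Compound 4 thus joins compound 1, so both halogen-bearing phenyl compounds shown stand only at a limit, not at a number: the limit of > 64000 nM in this assay, at which 2 of the 4 values shown sit. The step between compound 1 and compound 4 cannot be read, which leaves 3-chlorophenyl and 2-fluorophenyl unranked.

As far as these compounds go, it remains open whether a hydroxyl or an amine on the phenyl ring would match compound 2 and compound 3. From the compounds shown here alone, whether any group on this carbon can go beyond those two also remains open.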